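From Azetidine to Methylpyrrolidine: Expected Clearance of Compound 4

The source may report more compounds than this note shows. Statements on the series, on what has been measured and on what is new or still open speak of the compounds shown alone.

Compound 2 `O=C(CCSc1nc2cc(Cl)ccc2o1)N1CCC1` gives 17.9 mL/min/g in an ADME assay on microsomes from liver (Mus musculus) for metabolic stability, read by LC-MS, using NADPH, with a stated time of 45 min, tested at 0.5 uM (on this read-out higher numbers stand for fast clearance and lower numbers for slow clearance), the second highest of the three numbers measured. Its nearest neighbour is compound 3 `Clc1ccc2oc(SCCCN3CCCC3)nc2c1`, which gives 10.4 mL/min/g; a 1.7-fold lower number from compound 2 to compound 3 (0.24 log units; within the scatter). Compound 1 `O=C(CCSc1nc2ccccc2o1)N1CCCC1` gives 161 mL/min/g, a far higher number, but it differs from compound 2 in two places, so the two values alone say only that much. Compound 4 `CC1CCCN1C(=O)CCSc1nc2cc(Cl)ccc2o1` differs from compound 2 by 2-methylpyrrolidin-1-yl in place of azetidin-1-yl on a carbonyl carbon. Among the compounds with values here, no measured step alters only the group on the carbonyl carbon; the single measured step replaces the whole (azetidin-1-yl)carbonyl and stays within the scatter. A modest rise in this assay is therefore expected, a 1.7-fold higher number from compound 2 to compound 4 (0.22 log units; within the scatter). Compound 4 is estimated at 30 mL/min/g, with a range from 12 mL/min/g to 80 mL/min/g.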

Compound 4, intrinsic clearance in a liver preparation (reported as CLH), per the amount of preparation that the assay uses: 98 mL/min/g
Compound 4: the middle estimate sits 3.3-fold (0.51 log units) below what was measured; the whole stated range lies below it.
By their numbers in this assay, from the lowest: compounds 3 and 2 (each within the scatter of the next); then compounds 4 and 1 (each within the scatter of the next).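

Changing only the group on the carbonyl carbon gives a 5.5-fold higher number from compound 2 to compound 4 (0.74 log units; beyond the scatter) in this assay, so what sits at this position can shift clearance beyond the scatter. The earlier 1.7-fold lower number from compound 2 to compound 3 (0.24 log units; within the scatter) stayed within the scatter, although it replaced the whole (azetidin-1-yl)carbonyl. No measurement shown here explains the rise. The compounds shown leave open how much of the rise goes with the five-membered ring and how much with its methyl. They also leave open how a morpholin-4-yl on the same carbonyl carbon would read.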